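The compounds below may be only part of what the source reports. "The series", "measured", "known", "first", "only" and "open" are said of these compounds alone.

Measured compounds in an ADME assay on Huh-7 cells (Homo sapiens) for cytotoxicity, read by a luciferase reporter and WST assay, with a stated time of 3 days; on this read-out higher numbers stand for lower toxicity in this test and lower numbers for higher toxicity in this test:
compound 1 `COC(=O)CNC(=O)c1c(NO)cc(-c2ccccc2)oc1=O`; compound 1 gives > 20000 nM, a limit of the assay.
compound 2 `COC(=O)CNC(=O)c1c(NO)cc(-c2ccc(F)cc2)oc1=O`; compound 2 gives > 20000 nM, a limit of the assay.
compound 3 `COC(=O)CNC(=O)c1c(NO)cc(-c2ccc(Cl)cc2)oc1=O`; compound 3 gives > 20000 nM, a limit of the assay.

Compound 3 therefore stands at a limit only, with no number of its own. The two other values shown are also limits, so that all three sit at the same place (the limit of > 20000 nM in this assay, at which 3 of the 3 values shown sit). The steps within the measured set cannot be read: a step that the two limits leave unreadable from compound 1 to compound 2, a step that the two limits leave unreadable from compound 1 to compound 3 and a step that the two limits leave unreadable from compound 2 to compound 3 are all left unreadable by the limits.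

Compound 4 `COC(=O)CNC(=O)c1c(NO)cc(-c2ccc(C)cc2)oc1=O` differs from compound 3 in one place: methyl in place of chloro on an aromatic carbon. No measured step bears on this change with a readable size; the three steps shown only tell that none of the substituents tried moved the read-out off the limit. On that basis compound 4 is expected to stay at the limit as well, the step that the limit leaves unreadable from compound 3 to compound 4 meaning no change that could be read. The estimate for compound 4 in this assay is 30000 nM, within 15000 nM to 80000 nM.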

Compound 4, half-maximal cytotoxic concentration: > 20000 nM
Compound 4 ended at the assay's limit (the forecaster's own chance of this, stated with the estimate: 85%); the middle value lies beyond the limit too.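

Compound 4 sits at the same limit as compound 1, compound 2 and compound 3, so none of its steps to those compounds can be read: the limit of > 20000 nM in this assay, at which 4 of the 4 values shown sit.

The compounds shown leave open where any of the four truly lies in this assay, and whether any group at this place could bring the read-out off the limit.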